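This account rests on a few compounds, and the source may have more. Where it says the series, first, only, none or still open, it means among the compounds named here.

Measured compounds in an assay on Sf9 cells for inhibition of histone-lysine N-methyltransferase EZH2 (Homo sapiens), read by scintillation counting, with a stated time of 60 min, in the presence of a further agent that is not named here; a higher number here means a weaker inhibitor, a lower number a stronger inhibitor:
compound 1 `COc1cccc(C(=O)NCc2c(C)cc(C)[nH]c2=O)c1Cl` — 7200 nM
compound 2 `Cc1cc(C)c(CNC(=O)c2cccc(OC(C)C)c2Cl)c(=O)[nH]1` — 1300 nM
compound 3 `Cc1cc(C)c(CN2CCc3c(Cl)cc(-c4cn[nH]c4C)c(Cl)c3C2=O)c(=O)[nH]1` — 24 nM

Compound 1 gives the highest number of the three in this assay. Its nearest neighbour is compound 2, reached by the step of a 5.5-fold lower number from compound 1 to compound 2 (0.74 log units; beyond the scatter), and the furthest is compound 3, which shows a value far below that of compound 1 and carries a different core.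

The step under consideration leads from compound 1 to compound 4 `COc1cccc(C(=O)NCc2c(C)cc(C)[nH]c2=O)c1OC`: methoxy in place of chloro on an aromatic carbon. Among the measured compounds shown here, no measured step touches this position. For the measured compounds named here, the one measured step, a 5.5-fold lower number from compound 1 to compound 2 (0.74 log units; beyond the scatter), changes the alkoxy group and not the chloro, so it gives no direct guide; it shows only that this part of the molecule is sensitive to substitution. Compound 3 is too different to bear on the step. With nothing to anchor the direction, the expectation for compound 4 is a step of a 1.4-fold higher number from compound 1 to compound 4 (0.14 log units; within the scatter) in this assay, with wide uncertainty on either side. Compound 4 is thus estimated at 10000 nM, within a range of 3000 nM to 35000 nM.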

Compound 4, half-maximal inhibitory concentration in the histone-lysine N-methyltransferase EZH2 assay: > 140000 nM
Compound 4 was reported as a limit; the forecaster's own chance of this, stated with the estimate: 20%; at least 14-fold (1.14 log units) between middle value and limit.
By their numbers in the histone-lysine N-methyltransferase EZH2 assay, from the lowest: compound 3; then compound 2; then compound 1. At a limit, above all of these: compound 4.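

This aromatic carbon, ortho to a large group and ortho to a methoxy group, does not tolerate every small substituent: in the histone-lysine N-methyltransferase EZH2 assay, methoxy in place of chloro gives an at least 19-fold higher number from compound 1 to compound 4 (1.28 log units; beyond the scatter)
For compound 4 the reading is a limit, not a number, so the true size of the step stays undefined: the limit of > 140000 nM in the histone-lysine N-methyltransferase EZH2 assay, at which 1 of the 4 values shown sits.
In a physicochemical assay for lipophilicity, at pH 7.4 (a lower number here means a more polar compound, a higher number a more lipophilic compound), compound 1 gives 1.2 and compound 4 gives 1.7.
In the physicochemical assay compound 4 is the more lipophilic of the pair, so the loss in the histone-lysine N-methyltransferase EZH2 assay does not go with a fall in lipophilicity: the measured distribution coefficient of compound 1, 1.2, and of compound 4, 1.7, a number 0.50 log units higher (beyond the scatter)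

Open points: the compounds shown cannot separate an effect specific to methoxy from a general need for chloro, and methyl or bromo on this carbon would test that in the histone-lysine N-methyltransferase EZH2 assay. Also open, as far as these compounds go, is whether the same change costs as much on the isopropyl ether of compound 2 or on the core of compound 3.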